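The compounds below may be only part of what the source reports. "The series", "measured", "known", "first", "only" and "open" are said of these compounds alone.

Measured so far:
- compound 1 `Nc1ccccc1NC(=O)c1ccc(CSC(=S)N2CCc3ccccc32)cc1`: 67%
- compound 2 `CN(Cc1cccnc1)C(=S)SCc1ccc(C(=O)Nc2ccccc2N)cc1`: 68.7%

In a functional assay on HeLa cells (Homo sapiens) for antiproliferative activity, read by CCK-8 assay, with a stated time of 72 h, tested at 8 uM (on this read-out lower numbers stand for a weaker effect and higher numbers for a stronger effect at the one concentration tested), compound 1 gives 67%, and compound 2 gives 68.7%; the two numbers sit within the scatter of each other, so neither can be called stronger. Among the compounds with values here, the single measured step, a number 1.7 percentage points higher from compound 1 to compound 2 (within the scatter), exchanges the group on the thiocarbonyl carbon and leaves the read-out unchanged beyond the scatter.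

Compound 3 `Nc1ccccc1NC(=O)c1ccc(CSC(=S)N2CCc3ccc([N+](=O)[O-])cc32)cc1` differs from compound 1 by nitro in place of hydrogen on an aromatic carbon. Within the data shown here, no measured step alters a substituent on that fused ring, so the one known step bears on this change only loosely; it shows that a change at the thiocarbonyl end did not move the number. With nothing pointing either way, no step beyond the scatter is expected in this assay. The expected step is then no change at the digits printed from compound 1 to compound 3 (within the scatter), which stays within the scatter. Compound 3 is therefore estimated to give 67%, between 50% and 82%.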

Compound 3, a percentage reported as inhibition, at one concentration (the size of the read-out at that concentration, not a potency): 62.1%
For compound 3 the middle estimate is 4.9 percentage points above the measured one, and the stated range covers the measured number.
By their numbers in this assay, from the lowest: compounds 3, 1 and 2 (each within the scatter of the next).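

In this assay, placing nitro in place of hydrogen on an aromatic carbon of the ring system at the thiocarbonyl end gives a number 4.9 percentage points lower from compound 1 to compound 3 (within the scatter) and so does not separate the two compounds. The earlier step changed the whole group on the thiocarbonyl carbon, whereas this one shows that a substituent can be added to that group's six-membered aromatic ring with no change beyond the scatter at this single concentration. The data available give no explanation for this outcome.

The compounds shown leave open whether an amine or a carboxylic acid on this same carbon would also stay within the scatter, or whether nitro on another carbon of that ring would. A reading at one concentration also leaves open whether compound 1 and compound 3 would give a stronger or weaker effect than each other at any other concentration.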